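A few compounds are considered here, and "the series" means these few. Any claim that something is new, unique, unknown or untested is made for them only; others in the source may bear on it.

Measured in an ADME assay on HepG2 cells (Homo sapiens) for cytotoxicity, read by fluorescence and resazurin assay, with a stated time of 24 h; a lower number here means that less compound is tolerated, a higher number that more compound is tolerated:
compound 1 `CC(=O)Nc1ccc(-c2nnc(SC3=CS(=O)(=O)c4ccccc43)o2)cc1` gives 31000 nM
compound 2 `O=S1(=O)C=C(Sc2nnc(-c3ccc(Cl)cc3)o2)c2ccccc21` gives 22000 nM

Compound 2 and compound 1 stand within the scatter of each other, the step being a 1.4-fold lower number from compound 1 to compound 2 (0.15 log units; within the scatter), so neither can be called the more tolerated. Compound 3 `O=S1(=O)C=C(Sc2nnc(-c3ccccn3)o2)c2ccccc21` differs from compound 2 by pyridin-2-yl in place of 4-chlorophenyl on an aromatic carbon. Among the measured compounds shown here, the one measured step, a 1.4-fold lower number from compound 1 to compound 2 (0.15 log units; within the scatter), also swapped one group for another on an aromatic carbon and stayed within the scatter, so no movement beyond the scatter is expected in this assay. Compound 3 is expected to give 22000 nM, with a range from 10000 nM to 45000 nM, an estimated no change at the digits printed from compound 2 to compound 3 (within the scatter).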

Compound 3, half-maximal cytotoxic concentration: 24000 nM
Compound 3: the middle estimate sits 1.1-fold (0.04 log units) below what was measured, within the range that was stated.
By their numbers in this assay, from the lowest: compounds 2, 3 and 1 (each within the scatter of the next).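

In this assay, the step is a 1.1-fold higher number from compound 2 to compound 3 (0.04 log units; within the scatter), so the two compounds cannot be told apart. The earlier step changed only a group on the phenyl ring, whereas here the ring itself is replaced, with a ring nitrogen entering and the chlorine leaving, and the result still lies within the scatter. Nothing available explains this result. On these data alone, it remains open whether a group without an aromatic ring at this place, such as an amine or a longer alkyl chain, would give a step beyond the scatter.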